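This account rests on a few compounds, and the source may have more. Where it says the series, first, only, none or still open, it means among the compounds named here.

Among the compounds with values here, in a functional assay on MDA-MB-231 cells (Homo sapiens) for antiproliferative activity, read by sulforhodamine B assay (a lower number here means a stronger inhibitor of growth, a higher number a weaker inhibitor of growth), compound 3 `CCC(CC)COc1cccc(O)c1C(=O)/C=C/c1ccc(O)cc1` gives 3130 nM, the only true number in this small set. Compound 1 `CCCCCCOc1cccc(O)c1C(=O)/C=C/c1ccc(O)cc1` gives > 30000 nM, which is a limit of the assay. Compound 2 `O=C(/C=C/c1ccc(O)cc1)c1c(O)cccc1OCC1CCCCC1` gives > 30000 nM, also a limit.

Compound 4 `O=C(/C=C/c1ccc(O)cc1)c1c(O)cccc1OCCC1CCCC1` carries cyclopentylmethyl in place of pentan-3-yl on a saturated chain carbon bound to an oxygen on an aromatic ring. Within the data shown here, two measured steps bear on this change: an at least 9.5-fold lower number from compound 1 to compound 3 (0.98 log units; beyond the scatter) and an at least 9.5-fold lower number from compound 2 to compound 3 (0.98 log units; beyond the scatter). Going by these compounds, each starts from a limit, so its true size stays open, and a step that the two limits leave unreadable from compound 1 to compound 2 adds nothing readable.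

Of the three groups tested, only pentan-3-yl gives a number in this assay. The entering group has a ring, as does the cyclohexyl of compound 2, which moves to compound 3 with an at least 9.5-fold lower number from compound 2 to compound 3 (0.98 log units; beyond the scatter). Part of that step is therefore expected to be lost, and the assay may report only a limit. The expected change is a 4.8-fold higher number from compound 3 to compound 4 (0.68 log units; beyond the scatter), towards weaker growth inhibition. Compound 4 is estimated at 15000 nM, with an expected range of 3500 nM to 45000 nM.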

Compound 4, concentration for 50% growth inhibition: 3340 nM
Estimate against measurement, compound 4: 4.5-fold (0.65 log units) above; the whole stated range lies above it.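

In this assay, cyclopentylmethyl and pentan-3-yl cannot be told apart at this position, with a 1.1-fold higher number from compound 3 to compound 4 (0.03 log units; within the scatter), so a ring in this group is compatible with a measurable value, and compound 2 is the case that goes against any wider claim for ring groups. Moving from cyclohexyl to cyclopentylmethyl gives an at least 8.9-fold lower number from compound 2 to compound 4 (0.95 log units; beyond the scatter), which shows that the ring's presence alone does not decide the outcome here. Moving from the straight chain of compound 1 gives an at least 8.9-fold lower number from compound 1 to compound 4 (0.95 log units; beyond the scatter), and both of these steps start from the same assay limit, so their true sizes stay open: the limit of > 30000 nM in this assay, at which 2 of the 4 values shown sit.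

Going by these compounds, whether an amine or a carboxylic acid at this place would keep the growth inhibition remains open. The compounds shown also leave open how far any group here can take the value below those of compound 3 and compound 4.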